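The source may report more compounds than this note shows. Statements on the series, on what has been measured and on what is new or still open speak of the compounds shown alone.

In a functional assay on NCI-H460 cells (Homo sapiens) for cytotoxicity, read by MTT assay, with a stated time of 68 h (on this read-out lower numbers stand for stronger inhibition and higher numbers for weaker inhibition), compound 1, with the structure `O=C(Nc1cccc(-c2ccccc2C(F)(F)F)c1)C(Cl)Cl`, gives 7550 nM. Among the compounds with values here, compound 1 is the only compound of the three with a numerical value in this assay. Compound 2, with the structure `COc1cccc(-c2cc(NC(=O)C(Cl)Cl)cc(-c3cccc(OC)c3)c2)c1`, reaches only a limit of this assay, at > 30000 nM. Compound 3, with the structure `COc1ccc(-c2cc(NC(=O)C(Cl)Cl)cc(-c3ccc(OC)cc3)c2)cc1`, likewise reaches only a limit, at > 30000 nM. Within the data shown here, two of the three compounds thus sit at the limit of > 30000 nM in this assay, at which 2 of the 3 values shown sit, and no step between measured compounds that differ in a single place is available.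

Compound 4, with the structure `O=C(Nc1cccc(-c2ccccc2F)c1)C(Cl)Cl`, has not been measured in this assay. It differs from compound 1 by fluoro in place of trifluoromethyl on an aromatic carbon. Among the measured compounds shown here, with no comparable step among the measured compounds to draw on, the account rests on compound 1 alone, and a modest loss of potency is expected, though a step within the scatter cannot be ruled out. Compound 4 is estimated to give 12000 nM in this assay, within a range from 4000 nM to 30000 nM, which would mean a step of a 1.6-fold higher number from compound 1 to compound 4 (0.20 log units; within the scatter).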

Compound 4, half-maximal inhibitory concentration: 26800 nM
Compound 4: middle estimate off by 2.2-fold (0.35 log units), on the low side; the range from low to high includes it.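

Within the data shown here, the exchange of trifluoromethyl for fluoro, on an aromatic carbon ortho to a large group, gives the first comparison between two measured compounds in this assay, and it brings a 3.5-fold higher number from compound 1 to compound 4 (0.55 log units; beyond the scatter). This place on the ring is therefore not indifferent to the group it carries, and here trifluoromethyl gives the lower number of the two. Compound 4 still gives a number, 26800 nM, but the measurable scale ends not far from it: the limit of > 30000 nM in this assay, at which 2 of the 4 values shown sit.

The compounds shown leave open how a hydrogen, a methyl, a methoxy group or an amine would fare at this place, so this single pair gives a direction and no trend. Also open, from the compounds shown here alone, is whether the same step would appear on another core, since compound 2 and compound 3 differ from compound 1 in more than one place.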